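A few compounds are considered here, and "the series" means these few. Any claim that something is new, unique, unknown or untested is made for them only; others in the source may bear on it.

The study followed cytotoxicity in a toxicity assay on FHC cells (Homo sapiens) for cytotoxicity, read by resazurin assay, with a stated time of 48 h; a higher number here means that more compound is tolerated, a lower number that less compound is tolerated. Compound 1, `O=C(/C=C/c1ccccc1)c1ccc(NC(=O)c2cccs2)cc1`, carries a thiophen-2-yl on the amide carbonyl and an unsubstituted phenyl on the enone; in this assay compound 1 gives 83000 nM. Compound 2, `O=C(/C=C/c1cccc([N+](=O)[O-])c1)c1ccc(NC(=O)c2ccco2)cc1`, carries a nitro-bearing phenyl on the enone and a furan-2-yl on the amide carbonyl. For compound 2 this assay reports only a limit, > 100000 nM. This is the limit of > 100000 nM in this assay, at which 1 of the 2 values shown sits, so compound 2 stands at the edge of what this assay can report. For the measured compounds named here, no step between measured compounds is available here, so the two values can only be read side by side.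

Compound 3, `O=C(/C=C/c1cccc([N+](=O)[O-])c1)c1ccc(NC(=O)c2cccs2)cc1`, has not yet been measured. It differs from compound 2 by thiophen-2-yl in place of furan-2-yl on a carbonyl carbon. The thiophen-2-yl already appears on the amide carbonyl of compound 1, and in this assay compound 1 gives 83000 nM. The expected step of an at least 1.0-fold lower number from compound 2 to compound 3 (0.02 log units; that floor lies within the scatter) therefore amounts to nothing beyond the usual scatter. Compound 3 is expected to tolerate about 95000 nM, within a range from 45000 nM to 200000 nM, and may well be reported as a limit again.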

Compound 3, half-maximal cytotoxic concentration: 73000 nM
Estimate against measurement, compound 3: 1.3-fold (0.11 log units) above, within the range that was stated.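

With the nitro-bearing phenyl held fixed, thiophen-2-yl in place of furan-2-yl on the carbonyl carbon gives, in this assay, an at least 1.3-fold lower number from compound 2 to compound 3 (0.13 log units; that floor lies within the scatter), so this position now has a direct comparison, though one whose floor does not exceed the usual scatter. With thiophen-2-yl held fixed, nitro in place of hydrogen on an aromatic carbon gives a 1.1-fold lower number from compound 1 to compound 3 (0.06 log units; within the scatter), which lies within the scatter, so the two compounds of that pair cannot be told apart in this assay. The full size of the exchange of the two rings stays unknown, because compound 2 is reported only as a limit: the limit of > 100000 nM in this assay, at which 1 of the 3 values shown sits.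

The compounds shown leave open how the amide carbonyl position reads with something other than a five-membered aromatic ring on it, such as a methyl group or a longer alkyl chain. They also leave open whether an amine or a carboxylic acid in place of the nitro group on the aromatic carbon would give a step beyond the scatter.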